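A Smaller Ester Tail, Tested for Stability

The source may report more compounds than this note shows. Statements on the series, on what has been measured and on what is new or still open speak of the compounds shown alone.

Measured so far, in an ADME assay for metabolic stability, read by LC-MS, with a stated time of 3 h, at pH 6.5, tested at 50 uM; a lower number here means that less of the compound is left, a higher number that more of the compound is left:
Compound 1, `Cc1oc(=O)oc1COC(=O)c1cccc(NC(=O)[C@@H]2C[C@H](SC3=C(C(=O)O)N4C(=O)[C@H]([C@@H](C)O)[C@H]4[C@H]3C)CN2)c1`, gives > 95%, which is a limit of the assay.
Compound 2, `C[C@@H](O)[C@H]1C(=O)N2C(C(=O)OCOC(=O)C3CCCCC3)=C(S[C@@H]3CN[C@H](C(=O)Nc4cccc(C(=O)O)c4)C3)[C@H](C)[C@H]12`, gives > 95%, also a limit of the assay.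

For the measured compounds named here, compound 2 stands at the top of what this assay reports: its result is a limit, not a number, and it shares that position with the only other compound measured, since (the limit of > 95% in this assay, at which 2 of the 2 values shown sit). Neither value can be ranked against the other.

The step to compound 3, `COC(=O)OCOC(=O)C1=C(S[C@@H]2CN[C@H](C(=O)Nc3cccc(C(=O)O)c3)C2)[C@H](C)[C@@H]2[C@@H]([C@@H](C)O)C(=O)N12`, changes the group hanging on the ester that caps the acid of the shared core: methoxy in place of cyclohexyl on a carbonyl carbon. In words, methoxy in place of cyclohexyl on a carbonyl carbon. Going by the values given here, no step between two measured compounds is available to show how this kind of change moves the read-out, so the expectation rests on the two limits alone.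

With both measured compounds at the limit, the expectation for this step is no change beyond the scatter, that is a number no higher from compound 2 to compound 3 (the limit leaves the size open). Compound 3 is therefore estimated at 95%, with a range from 85% to 99%.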

Compound 3, percent of the compound remaining: > 95%
Compound 3 ended at the assay's limit (the forecaster's own chance of this, stated with the estimate: 75%); the middle value lies on the limit itself.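

The step from compound 2 to compound 3 cannot be read in this assay, and the reason is one shared limit: the limit of > 95% in this assay, at which 3 of the 3 values shown sit. As far as these compounds go, what remains open is whether methoxy in place of cyclohexyl on a carbonyl carbon changes how much of the compound is left, and how the three compounds would rank if their results were numbers rather than limits.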